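Aryl variation on the shared core against NF-kappa-B

A few compounds are considered here, and "the series" means these few. Any claim that something is new, unique, unknown or untested is made for them only; others in the source may bear on it.

Compound 1 `CCOC(=O)c1cnc(-c2ccccc2)nc1NN1C(=O)C=C(C)C1=O` carries a plain phenyl group; in a functional assay on Jurkat cells for inhibition of nuclear factor NF-kappa-B complex (Homo sapiens) (a higher number here means a weaker inhibitor, a lower number a stronger inhibitor), compound 1 gives 100 nM. Compound 2 `CCOC(=O)c1cnc(-c2cc(Cl)nc(Cl)c2)nc1NN1C(=O)C=C(C)C1=O` gives 2000 nM in this assay, and compound 3 `CCOC(=O)c1cnc(-c2ccc(OC)cc2)nc1NN1C(=O)C=C(C)C1=O` gives 900 nM. Compound 3 stands second highest of the three numbers: a 2.2-fold lower number from compound 2 to compound 3 (0.35 log units; beyond the scatter), while a 9.0-fold higher number from compound 1 to compound 3 (0.95 log units; beyond the scatter).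

Compound 4 `CCOC(=O)c1cnc(-c2cccc(Br)c2)nc1NN1C(=O)C=C(C)C1=O` is not yet measured. The change from compound 3 is 3-bromophenyl in place of 4-methoxyphenyl on an aromatic carbon. Among the compounds with values here, no measured step involves a bromine, so the comparison rests on the two aryl variations seen so far, both of which weakened inhibition relative to the plain phenyl: a 9.0-fold higher number from compound 1 to compound 3 (0.95 log units; beyond the scatter) and a 20-fold higher number from compound 1 to compound 2 (1.30 log units; beyond the scatter). A substituted phenyl without the methoxy acceptor may sit anywhere between those two outcomes, so only a modest change from compound 3 is anticipated in this assay, most likely toward a lower number, though possibly none beyond the scatter. The expected step is a 1.8-fold lower number from compound 3 to compound 4 (0.26 log units; within the scatter). Compound 4 is therefore estimated at 500 nM, with a range from 150 nM to 2000 nM.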

Compound 4, half-maximal inhibitory concentration: 700 nM
Estimate against measurement, compound 4: 1.4-fold (0.15 log units) below; the range from low to high includes it.
By their numbers in this assay, from the lowest: compound 1; then compounds 4 and 3 (each within the scatter of the next); then compound 2.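

At the aromatic carbon between two ring nitrogen atoms, a bromine-bearing phenyl also falls short of plain phenyl, with a 7.0-fold higher number from compound 1 to compound 4 (0.85 log units; beyond the scatter) in this assay, so the gap is not peculiar to 4-methoxyphenyl, and all three substituted aryl groups give higher numbers than plain phenyl. Exchanging 4-methoxyphenyl for 3-bromophenyl gives a 1.3-fold lower number from compound 3 to compound 4 (0.11 log units; within the scatter), so these two aryl groups are not told apart even though the substituent and its ring position both change, whereas replacing 2,6-dichloropyridin-4-yl with 3-bromophenyl gives a 2.9-fold lower number from compound 2 to compound 4 (0.46 log units; beyond the scatter) on the same carbon. No independent evidence bears on these differences.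

Open, as far as these compounds go, is whether the substituent itself or its ring position sets the number. Also open, from the compounds shown here alone, is how an amine or a carboxylic acid on the phenyl ring would compare with plain phenyl.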